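The source may hold more compounds than are shown below. What is called first, only, known or untested is meant among the compounds shown, and "the series" means these compounds.

In a functional assay on HT-29 cells (Homo sapiens) for antiproliferative activity, read by MTT assay, with a stated time of 24 h (on this read-out higher numbers stand for weaker inhibition and lower numbers for stronger inhibition), compound 2 `COc1ccc(C(=O)/C=C/c2ccc(F)cc2)c2c1C=CC(C)(C)O2` gives only a limit, > 10000 nM. Compound 1 `COc1cccc(/C=C/C(=O)c2ccc(OC)c3c2OC(C)(C)C=C3)c1` likewise sits at a limit, > 10000 nM. Compound 3 `COc1ccc(C(=O)/C=C/c2cccc([N+](=O)[O-])c2)c2c1C=CC(C)(C)O2` gives a number, 4260 nM. Compound 2 therefore stands at the limit shared with compound 1 (the limit of > 10000 nM in this assay, at which 2 of the 3 values shown sit), and only compound 3 lies beneath it. The change to compound 4 `COc1ccc(C(=O)/C=C/c2cccc(O)c2)c2c1C=CC(C)(C)O2` is 3-hydroxyphenyl in place of 4-fluorophenyl on a double-bonded chain carbon bound to a double-bonded chain carbon. The measured steps that bear on it are an at least 2.3-fold lower number from compound 2 to compound 3 (0.37 log units; beyond the scatter) and an at least 2.3-fold lower number from compound 1 to compound 3 (0.37 log units; beyond the scatter), both bringing in a nitro group; a step that the two limits leave unreadable from compound 1 to compound 2 is unreadable. Within the data shown here, no measured step carries a hydroxy group. One expects compound 4 to remain near the limit, a step that the limit leaves unreadable from compound 2 to compound 4 of no size beyond the scatter. One estimates compound 4 at 12000 nM, between 3000 nM and 40000 nM.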

Compound 4, half-maximal inhibitory concentration: > 10000 nM
Compound 4 was reported as a limit; the forecaster's own chance of this, stated with the estimate: 60%; the middle value lies beyond the limit too.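

Compound 4, with 3-hydroxyphenyl in place of 4-fluorophenyl, is reported in this assay only as a limit: the limit of > 10000 nM in this assay, at which 3 of the 4 values shown sit. The steps that join two limits cannot be read. Hydroxy in place of nitro on an aromatic carbon gives an at least 2.3-fold higher number from compound 3 to compound 4 (0.37 log units; beyond the scatter), so hydroxy, like the methoxy of compound 1, does not match the nitro group of compound 3, the only compound shown that gives a number.

On these data alone, it remains open whether an amine or a carboxylic acid on that aromatic carbon would give a number. As far as these compounds go, the order among compound 1, compound 2 and compound 4 also stays unknown.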